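A few compounds are considered here, and "the series" means these few. Any claim that something is new, unique, unknown or untested is made for them only; others in the source may bear on it.

Measured compounds:
- Compound 1, `Cc1ccc(NC(=S)NC(=O)c2ccc(OCc3cccc(F)c3)cc2)cc1-c1nc2ccccc2[nH]1`: 55300 nM
- Compound 2, `Cc1ccc(NC(=O)NC(=O)c2ccc(OCc3ccccc3)cc2)cc1-c1nc2ccccc2[nH]1`: 16400 nM

Both compounds were tested in a functional assay on HT-29 cells (Homo sapiens) for inhibition, read by MTT assay, with a stated time of 48 h; a higher number here means a weaker inhibitor, a lower number a stronger inhibitor. Among the two numbers, compound 2 has the lower one, at 16400 nM, and the nearest neighbour is compound 1, whose value of 55300 nM lies beyond the scatter of repeated measurements, so compound 2 reads as the stronger inhibitor of the pair. For the measured compounds named here, the two differ in more than one place, so no single step between them is counted here; only their two values can be compared.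

Compound 3, `Cc1ccc(NC(=O)NC(=O)c2ccc(OCc3cccc(Cl)c3Cl)cc2)cc1-c1nc2ccccc2[nH]1`, has not yet been measured. It is built from compound 2 by one change: 2,3-dichlorophenyl in place of phenyl on a saturated chain carbon bound to an oxygen on an aromatic ring. Going by the values given here, no measured pair shows this change on its own, so its effect has to be guessed. Because compound 2 already gives 16400 nM, only a moderate move towards a lower number is expected, and the step is estimated at a 1.6-fold lower number from compound 2 to compound 3 (0.21 log units; within the scatter). Compound 3 is therefore estimated at 10000 nM, with a range from 3000 nM to 40000 nM.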

Compound 3, half-maximal inhibitory concentration: 48500 nM
Compound 3: middle estimate off by 4.9-fold (0.69 log units), on the low side; measured number above the stated range.
By their numbers in this assay, from the lowest: compound 2; then compounds 3 and 1 (each within the scatter of the next).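

For the compounds shown here, this is the first change in a single place that can be read in this assay: 2,3-dichlorophenyl in place of phenyl, on a saturated chain carbon bound to an oxygen on an aromatic ring, gives a 3.0-fold higher number from compound 2 to compound 3 (0.47 log units; beyond the scatter). The group at this position therefore affects the read-out, and here the two added chlorine atoms go with weaker inhibition rather than stronger, leaving the unsubstituted phenyl with the lower number of this pair. No measurement here accounts for this shift, so the data give no cause for it.

Going by these compounds, it remains open whether a single chlorine would produce a similar step or whether the shift needs both chlorine atoms, and compound 1 cannot settle this, since it carries a fluorine on the same ring but also differs from compound 2 at the carbonyl of the shared chain. On these data alone, how this position would respond to a quite different group, such as a methoxy group or an amine on the ring, also remains open.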